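Aryl sulfonate ureas: the same swap, seen twice

The source may hold more compounds than are shown below. What is called first, only, known or untested is meant among the compounds shown, and "the series" means these compounds.

Compound 1, `CCc1ccccc1OS(=O)(=O)c1cccc(NC(=O)NCCCCl)c1`, gives 25000 nM in a functional assay on MCF7 cells (Homo sapiens) for cytotoxicity, read by sulforhodamine B assay, with a stated time of 48 h; a lower number here means a stronger inhibitor, a higher number a weaker inhibitor.
Compound 2, `O=C(NCCCCl)Nc1cccc(S(=O)(=O)Oc2ccc(O)cc2)c1`, gives 51000 nM in this assay.
Compound 3, `CCNC(=O)Nc1ccc(S(=O)(=O)Oc2ccccc2CC)cc1`, gives 3400 nM in this assay.

Among the three measured compounds, compound 3 carries the lowest number, and its steps to compound 1 and to compound 2 are both beyond the scatter. Compound 1 and compound 2 share a core and differ in one place: 4-hydroxyphenyl in place of 2-ethylphenyl on an oxygen. That change made a modest step, a 2.0-fold higher number from compound 1 to compound 2 (0.31 log units; beyond the scatter).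

Compound 4, `CCNC(=O)Nc1ccc(S(=O)(=O)Oc2ccc(O)cc2)cc1`, has not been measured in this assay. It stands to compound 3 as compound 2 stands to compound 1: 4-hydroxyphenyl in place of 2-ethylphenyl on an oxygen. The place is described in the same words in both pairs, so this is the same change, made on a different core. How the core of compound 3 differs from the core of compound 1 is not broken down here.

Among the compounds with values here, only one earlier instance of the change exists, and it rests on a single pair, so the expectation for compound 4 is held loosely. The number for compound 4 is expected to rise relative to compound 3 by about the step seen before, that is an expected 2.1-fold higher number from compound 3 to compound 4 (0.31 log units; beyond the scatter), because the same change gave a 2.0-fold higher number from compound 1 to compound 2 (0.31 log units; beyond the scatter). Compound 4 is therefore estimated at 7000 nM, with a plausible range from 2500 nM to 20000 nM.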

Compound 4, half-maximal inhibitory concentration: 8000 nM
Compound 4: middle estimate off by 1.1-fold (0.06 log units), on the low side, within the range that was stated.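

In this assay, the swap of 2-ethylphenyl for 4-hydroxyphenyl on the oxygen bound to the sulfonyl sulfur gave a 2.4-fold higher number from compound 3 to compound 4 (0.37 log units; beyond the scatter), a modest step in the same direction as the one on the core of compound 1. Set side by side, the two steps do not differ in any way these data can resolve: the same change on two cores in this assay, a 2.0-fold higher number (0.31 log units; beyond the scatter) from compound 1 to compound 2 and a 2.4-fold higher number (0.37 log units; beyond the scatter) from compound 3 to compound 4, 1.2-fold (0.06 log units) apart, within the scatter of two such steps. For this one change, then, the size of the step carried over between these two cores, but two pairs make no rule for the series, and they show neither why the steps agree nor which part of the swap, the loss of 2-ethylphenyl or the arrival of 4-hydroxyphenyl, produces them.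

The compounds shown leave open whether the step would hold for other groups on that oxygen, such as a 4-methoxyphenyl or a 4-aminophenyl group, or on a third core. They also leave open how the step would behave if the chain on the urea were replaced by a longer chain or one ending in a carboxylic acid, and the difference between the two cores is not taken apart here.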